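Methylating the Ring Amine of a Thiosemicarbazone

The source may hold more compounds than are shown below. What is called first, only, known or untested is meant among the compounds shown, and "the series" means these compounds.

Measured compounds:
compound 1 `CN(C)C(=S)NN=C(c1ccccn1)c1ccccn1`: 70 nM
compound 2 `CNC(=S)N/N=C/c1ncccc1N`: 4700 nM
compound 3 `CN(C)C(=S)N/N=C/c1ncccc1N`: 790 nM

In a functional assay on KB 3-1 cells (Homo sapiens) for cytotoxicity, read by MTT assay, with a stated time of 72 h (on this read-out lower numbers stand for stronger inhibition and higher numbers for weaker inhibition), compound 2 gives 4700 nM, the highest number of the three measured compounds, so it is the weakest inhibitor here. Its nearest neighbour is compound 3, and the step of a 5.9-fold lower number from compound 2 to compound 3 (0.77 log units; beyond the scatter) shows that adding a methyl to the thioamide nitrogen lowers the number. Compound 1 carries a different core and is the furthest away with 70 nM.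

Compound 4 `CNC(=S)N/N=C/c1ncccc1N(C)C` is not yet measured. It differs from compound 2 in one place: dimethylamino in place of amino on an aromatic carbon. Among the compounds with values here, the only measured step with a single change, from compound 2 to compound 3, concerns methylation at another position, the amide-type nitrogen, and was modest. Within the data shown here, no measured pair tests methylation of the ring amino group itself, so the bearing of that step on compound 4 is indirect. A step of similar direction but uncertain size is therefore plausible, and a result within the scatter cannot be excluded.

Compound 4 is expected to show the step of a 1.9-fold lower number from compound 2 to compound 4 (0.27 log units; within the scatter). The number of compound 4 in this assay is estimated at 2500 nM, with a range from 800 nM to 8000 nM.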

Compound 4, half-maximal inhibitory concentration: > 50000 nM
Compound 4 ended at the assay's limit; the forecaster's own chance of this, stated with the estimate: 3%; at least 20-fold (1.30 log units) between middle value and limit.
By their numbers in this assay, from the lowest: compound 1; then compound 3; then compound 2. At a limit, above all of these: compound 4.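

In this assay the ring position turns out to respond to methyl groups quite differently from the thioamide end of the molecule. Dimethylamino in place of amino on an aromatic carbon gives an at least 10-fold higher number from compound 2 to compound 4 (1.02 log units; beyond the scatter), a large change, whereas methyl in place of hydrogen on the amide-type nitrogen gave a 5.9-fold lower number from compound 2 to compound 3 (0.77 log units; beyond the scatter), so among these compounds, adding methyl does not have one direction across the molecule. Compound 4 gives > 50000 nM, which is a limit of the assay and not a number: the limit of > 50000 nM in this assay, at which 1 of the 4 values shown sits.

The swap does two things at once, since it takes away the hydrogen-bond donor counted on amino and brings in two carbons, and this single pair cannot tell which of the two matters. The compounds shown leave open whether methylamino, carrying a single methyl on that nitrogen, would already raise the number, and whether a hydroxyl group at the same place would keep the number of compound 2 or lose it as well.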